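The source may report more compounds than this note shows. Statements on the series, on what has been measured and on what is new or still open speak of the compounds shown alone.

Of the compounds shown here, three sharing one core have been measured so far. Compound 1 `CC(C)=CCOc1ccc2c(c1)OC(c1ccccc1)CC2=O` carries a plain phenyl ring on the saturated ring carbon and gives 6070 nM in a functional assay; on this read-out higher numbers stand for weaker inhibition and lower numbers for stronger inhibition. Compound 2 `CC(C)=CCOc1ccc2c(c1)OC(c1ccccc1F)CC2=O` places a fluorine on that ring and gives 6360 nM in this assay; compound 3 `CC(C)=CCOc1ccc2c(c1)OC(c1cccc(F)c1)CC2=O` places the fluorine elsewhere on the same ring and gives 4280 nM in this assay. Compound 3 has the lowest of the three numbers, yet the step of a 1.4-fold lower number from compound 1 to compound 3 (0.15 log units; within the scatter) and the step of a 1.5-fold lower number from compound 2 to compound 3 (0.17 log units; within the scatter) both fall within the scatter, as does a 1.0-fold higher number from compound 1 to compound 2 (0.02 log units; within the scatter), so the three compounds cannot be ranked.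

Compound 4 `CC(C)=CCOc1ccc2c(c1)OC(c1cccc(Cl)c1)CC2=O` differs from compound 3 by one change: chloro in place of fluoro on an aromatic carbon. Within the data shown here, no measured step swaps one halogen for another; the only halogen steps seen, from compound 1 to compound 2 and from compound 1 to compound 3, put fluoro in place of hydrogen and stayed inside the scatter. Because a 1.4-fold lower number from compound 1 to compound 3 (0.15 log units; within the scatter) was so small, the expectation for compound 4 is a step of about a 1.1-fold lower number from compound 3 to compound 4 (0.05 log units; within the scatter) in this assay, not clearly beyond the scatter in either direction. Compound 4 is therefore estimated at 3800 nM, with a likely range from 1900 nM to 7600 nM.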

Compound 4, half-maximal inhibitory concentration: 6300 nM
Estimate against measurement, compound 4: 1.7-fold (0.22 log units) below; low and high end bracket the measured number.
By their numbers in this assay, from the lowest: compounds 3, 1, 4 and 2 (each within the scatter of the next).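

In this assay, among these compounds, the first halogen-for-halogen swap on this aromatic carbon, chloro in place of fluoro, gives a step that stays within the usual scatter (a 1.5-fold higher number from compound 3 to compound 4 (0.17 log units; within the scatter)). Chloro in place of hydrogen on the plain phenyl ring of compound 1 also stays within the scatter (a 1.0-fold higher number from compound 1 to compound 4 (0.02 log units; within the scatter)), as does the change of the 2-fluorophenyl group to the 3-chlorophenyl group (a 1.0-fold lower number from compound 2 to compound 4 (0.00 log units; within the scatter)), so the four compounds still cannot be ranked, and on this ring hydrogen, fluoro and chloro cannot be told apart by this read-out. No supporting measurement is available that could account for this flat result.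

As far as these compounds go, what remains open is whether any group on this ring can move the number clearly beyond the scatter, for example a methoxy group, an amine, a carboxylic acid or a nitrile. From the compounds shown here alone, the four compounds also say nothing about changes elsewhere on the shared core, so the importance of the rest of the molecule for this read-out is still unknown.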